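The source may hold more compounds than are shown below. What is called first, only, known or untested is meant among the compounds shown, and "the series" means these compounds.

Measured compounds:
Compound 1 `COc1ccc2[nH]c(C(=O)N3CC(=O)N(Cc4ccccc4)[C@@H](COc4ccccc4)C3)cc2c1` gives 12200 nM in a physicochemical assay for solubility, read by spectrophotometry, in phosphate buffer, with a stated time of 2 h, at pH 7.4; on this read-out higher numbers stand for higher solubility and lower numbers for lower solubility.
Compound 2 `COc1ccc2[nH]c(C(=O)N3CC(=O)N(Cc4ccccc4)[C@@H](N4[C@H](C)CCC[C@@H]4C)C3)cc2c1` gives 100000 nM in this assay.

Among the measured compounds shown here, compound 2 holds the higher of the two numbers in this assay; its only neighbour is compound 1, and the change from one to the other gave an 8.2-fold higher number from compound 1 to compound 2 (0.91 log units; beyond the scatter). The next compound, compound 3 `COc1ccc2[nH]c(C(=O)N3CC(=O)N(Cc4ccccc4)[C@@H](COc4ccc(F)cc4)C3)cc2c1`, is reached from compound 2 by (4-fluorophenoxy)methyl in place of 2,6-dimethylpiperidin-1-yl on a saturated ring carbon. For the measured compounds named here, this change largely undoes the one that separates compound 1 from compound 2: the group that enters matches the phenoxymethyl of compound 1 apart from the fluorine on the aromatic ring. Going by the values given here, the single step that bears on it is therefore an 8.2-fold higher number from compound 1 to compound 2 (0.91 log units; beyond the scatter), read in reverse, and on that basis a fall of roughly the same size is expected in this assay, landing compound 3 close to compound 1. Among the compounds with values here, there is no measured step that shows what the fluorine alone does, so the expected step is a 10-fold lower number from compound 2 to compound 3 (1.00 log units; beyond the scatter). Compound 3 is estimated at 10000 nM in this assay, with a range from 4000 nM to 25000 nM.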

Compound 3, solubility: 17500 nM
Compound 3: middle estimate off by 1.8-fold (0.24 log units), on the low side; the range from low to high includes it.
By their numbers in this assay, from the lowest: compounds 1 and 3 (each within the scatter of the next); then compound 2.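

In this assay, replacing 2,6-dimethylpiperidin-1-yl with (4-fluorophenoxy)methyl on this saturated ring carbon gives a 5.7-fold lower number from compound 2 to compound 3 (0.76 log units; beyond the scatter) and so shows that the higher number of compound 2 stands apart from a second compound with an aromatic ether side group, not from compound 1 alone. The new comparison of fluoro with hydrogen on the aromatic carbon gives a 1.4-fold higher number from compound 1 to compound 3 (0.16 log units; within the scatter) and lies within the scatter, so in this pair the fluorine brings no change that can be told apart, and the larger difference at this position stays with the exchange of the whole side group. No measurement offered here accounts for the difference between these side groups.

The compounds shown leave open whether the higher number of compound 2 goes with the nitrogen of the side group, with its two methyl groups or with the saturated ring itself, which an unsubstituted piperidin-1-yl or a morpholin-4-yl on the same carbon could separate. They also leave open how a methoxy group or a carboxylic acid in place of the fluorine on the aromatic ring would read.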